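A few compounds are considered here, and "the series" means these few. Any claim that something is new, unique, unknown or untested is made for them only; others in the source may bear on it.

Measured compounds:
compound 1 `COc1ccc(-c2cc(/C=C/C(=O)c3ccc(N)cc3)[nH]n2)cc1` — -62%
compound 2 `COc1cc(-c2cc(/C=C/C(=O)c3ccc(Cl)c(Cl)c3)[nH]n2)cc(OC)c1OC` — -13%

Working notes on the series. Both measured compounds share a core that carries an aryl-substituted pyrazole joined through an enone to a second aryl ring. In a functional assay on MDA-MB-468 cells (Homo sapiens) for cytotoxicity, read by sulforhodamine B assay, with a stated time of 48 h, tested at 10 uM (a lower number here means a stronger effect, a higher number a weaker effect of the compound at the concentration tested), compound 1 gives -62% and compound 2 gives -13%. Compound 1 stands lowest of the two numbers; its nearest neighbour is compound 2, a number higher by a gap beyond the scatter. The two differ in more than one place, so no single change can be read from that gap.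

Compound 3 `COc1ccc(-c2cc(/C=C/C(=O)c3ccc(N)cc3)[nH]n2)cc1OC` is the next member to be measured. Relative to compound 1 it differs as follows: methoxy in place of hydrogen on an aromatic carbon. For the measured compounds named here, no directly comparable step exists among the measured compounds; the only reference is that, while carrying more methoxy groups than compound 1, compound 2 sits at -13%, but other parts of compound 2 also differ.

Expectation for compound 3 in this assay: a modest weakening, not clearly beyond the scatter, is estimated, giving a step of a number 17 percentage points higher from compound 1 to compound 3 (beyond the scatter). Compound 3 is expected to give -45% with a range of -75% to -10%.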

Compound 3, a percentage reported as activity, at one concentration (the size of the read-out at that concentration, not a potency): -65%
The estimate for compound 3 lay 20 percentage points above the measured number, and the stated range covers the measured number.
By their numbers in this assay, from the lowest: compounds 3 and 1 (each within the scatter of the next); then compound 2.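

Working notes, continued. In this assay, methoxy in place of hydrogen on an aromatic carbon, ortho to a methoxy group and meta to a large group, gives a number 3 percentage points lower from compound 1 to compound 3 (within the scatter). For the compounds shown here, this is the first step that can be read at a single place, and it shows that with the rest of the core of compound 1 held fixed, the added methoxy leaves compound 3 at -65%, within the scatter of compound 1 at -62%, so this change does not separate the two compounds in this read-out at the one concentration tested. No measurement at hand bears on the origin of this result.

Open, on these data alone, is whether a different group at this same place, such as a hydroxy, a fluorine or an ethoxy, would also stay within the scatter of compound 1. Also open, as far as these compounds go, is whether the methoxy step would read the same with a group other than the amine on the second aryl ring, such as an acetamide or a chlorine.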